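A few compounds are considered here, and "the series" means these few. Any claim that something is new, unique, unknown or untested is made for them only; others in the source may bear on it.

Compound 1 `CN(C)C(=O)c1cccnc1NCCCN1CCN(c2ccccc2O)CC1`: 5.01 nM
Compound 2 `CN(C)C(=O)c1cccnc1NCCCN1CCN(c2ccccc2-c2ncco2)CC1`: 0.316 nM

In a functional assay for antagonist activity at Alpha-1A adrenergic receptor (Oryctolagus cuniculus) (on this read-out higher numbers stand for weaker binding and lower numbers for tighter binding), compound 2 has the lower of the two numbers, set apart by the large step of a 16-fold lower number from compound 1 to compound 2 (1.20 log units; beyond the scatter). Compound 3 `CSc1ccccc1N1CCN(CCCNc2ncccc2C(=O)N(C)C)CC1` differs from compound 2 by methylsulfanyl in place of 1,3-oxazol-2-yl on an aromatic carbon. Among the compounds with values here, the one measured step that bears on this change is a 16-fold lower number from compound 1 to compound 2 (1.20 log units; beyond the scatter), and the group that now enters is neither of those two. The expected outcome is therefore a partial return toward a higher number, a 6.3-fold higher number from compound 2 to compound 3 (0.80 log units; beyond the scatter), smaller than that measured step. The estimate for compound 3 in this assay is 2 nM, within 0.5 nM to 8 nM.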

Compound 3, dissociation constant: 0.631 nM
The estimate for compound 3 lay 3.2-fold (0.50 log units) above the measured number; the range from low to high includes it.
By their numbers in this assay, from the lowest: compounds 2 and 3 (each within the scatter of the next); then compound 1.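

At this aromatic carbon, ortho to a large group, methylsulfanyl, with no ring, does about as well as 1,3-oxazol-2-yl in this assay, with a 2.0-fold higher number from compound 2 to compound 3 (0.30 log units; within the scatter). A five-membered aromatic ring is therefore not required here for a low number, and methylsulfanyl also stands clear of hydroxy, with a 7.9-fold lower number from compound 1 to compound 3 (0.90 log units; beyond the scatter). No evidence is available to explain either step. Still open, on these data alone, is how a methoxy group, an amine or a carboxylic acid on this carbon would compare, and whether methylsulfanyl would keep its number on another carbon of the ring.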